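The source may report more compounds than this note shows. Statements on the series, on what has been measured and on what is new or still open speak of the compounds shown alone.

Compound 1, `CCOC(=O)CNC(=O)NC1=CS(=O)(=O)O[C@@]12[C@@H](CO[Si](C)(C)C(C)(C)C)O[C@@H](n1cc(C)c(=O)n(C)c1=O)[C@@H]2O[Si](C)(C)C(C)(C)C`, gives 16000 nM in a functional assay on HEL cells (Homo sapiens) for cytotoxicity, read by microscopy; a higher number here means that more compound is tolerated, a lower number that less compound is tolerated.
Compound 2, `Cc1cn([C@@H]2O[C@H](CO[Si](C)(C)C(C)(C)C)[C@@]3(OS(=O)(=O)C=C3NC(=O)c3ccccc3)[C@H]2O[Si](C)(C)C(C)(C)C)c(=O)n(C)c1=O`, gives >= 3200 nM in this assay, and that value is a limit.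
Compound 3, `COC(=O)C(=O)CNC1=CS(=O)(=O)O[C@@]12[C@@H](CO[Si](C)(C)C(C)(C)C)O[C@@H](n1cc(C)c(=O)n(C)c1=O)[C@@H]2O[Si](C)(C)C(C)(C)C`, gives > 400000 nM in this assay, and that value is a limit as well.

Compound 3 therefore stands at the top of the numbers shown, at the limit of > 400000 nM in this assay, at which 1 of the 3 values shown sits, and compound 2 stands at the limit of >= 3200 nM in this assay, at which 1 of the 3 values shown sits. Within the data shown here, the one readable step is an at least 25-fold higher number from compound 1 to compound 3 (1.39 log units; beyond the scatter). The steps a step that the limit leaves unreadable from compound 1 to compound 2 and a step that the two limits leave unreadable from compound 2 to compound 3 give no size. Compound 4, `COC(=O)CCNC1=CS(=O)(=O)O[C@@]12[C@@H](CO[Si](C)(C)C(C)(C)C)O[C@@H](n1cc(C)c(=O)n(C)c1=O)[C@@H]2O[Si](C)(C)C(C)(C)C`, is not yet measured; it differs from compound 3 by (methoxycarbonyl)methyl in place of (methoxycarbonyl)carbonyl on a saturated chain carbon bound to an amine nitrogen. Among the measured compounds shown here, no measured step touches this part of the chain, so the readable step only says where compound 3 already sits. He expects compound 4 to stay high in this assay, though possibly below the limit, which means a step of an at least 2.6-fold lower number from compound 3 to compound 4 (0.42 log units; beyond the scatter). He estimates compound 4 at 150000 nM, between 20000 nM and 400000 nM.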

Compound 4, minimum cytotoxic concentration: >= 400000 nM
Compound 4: a limit, no number; the forecaster's own chance of this, stated with the estimate: 45%; at least 2.6-fold (0.42 log units) between middle value and limit.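

With the (methoxycarbonyl)carbonyl of compound 3 exchanged for (methoxycarbonyl)methyl, on a saturated chain carbon bound to an amine nitrogen, compound 4 still gives no number in this assay and stands at a limit: the limit of >= 400000 nM in this assay, at which 1 of the 4 values shown sits.

Removing that carbonyl from the chain therefore did not bring the value down to a measurable number, and the readable comparison is an at least 25-fold higher number from compound 1 to compound 4 (1.39 log units; beyond the scatter). The steps to compound 4 from compound 2 and from compound 3 cannot be read, so no size can be given for this change.

Going by these compounds, how far compound 3 and compound 4 lie past their limits stays open, and so does their order. Also open, on these data alone, is whether a carboxylic acid in place of the methyl ester of the 2-(methoxycarbonyl)ethyl group, or a longer chain, would stay at such a limit in this assay.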